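Furan-3-yl in place of oxolan-3-yl in compound 1

The source may report more compounds than this note shows. Statements on the series, on what has been measured and on what is new or still open speak of the compounds shown alone.

For the measured compounds named here, in a physicochemical assay for solubility, read by mass spectrometry, in phosphate buffer, with a stated time of 24 h, at pH 7.4 (a higher number here means a more soluble compound, a lower number a less soluble compound), compound 1 `O=C(Nc1ccc(OC(F)(F)F)cc1)NC1CCN(C(=O)[C@@H]2CCOC2)CC1` gives 23 ug/mL and holds the highest of the three numbers measured so far. Compound 2 `O=C(Nc1ccc(C(F)(F)F)cc1)NC1CCN(C(=O)[C@@H]2CCOC2)CC1` reads 1.4 ug/mL and compound 3 `CC[C@H](C)C(=O)N1CCC(NC(=O)Nc2ccc(C(F)(F)F)c(F)c2)CC1` reads 0.46 ug/mL on the same scale.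

The unmeasured compound 4 `O=C(Nc1ccc(OC(F)(F)F)cc1)NC1CCN(C(=O)c2ccoc2)CC1` differs from compound 1 in one place, with furan-3-yl in place of oxolan-3-yl on a carbonyl carbon.

Going by the values given here, the only measured step that changes a single place is a 16-fold lower number from compound 1 to compound 2 (1.22 log units; beyond the scatter) and it is large. That step puts trifluoromethyl in place of trifluoromethoxy on an aromatic carbon, which is a different change elsewhere in the molecule. It gives no direct guide to this exchange and shows only that one substitution can move the number a long way in this assay here. Compound 3 differs from compound 1 in more than one place, so it offers no clean comparison.

Among the compounds with values here, with compound 1 at 23 ug/mL as the starting point and no measured pair covering this exchange, the expectation is loose: a modest fall, perhaps none beyond the scatter. The expected step is a 1.9-fold lower number from compound 1 to compound 4 (0.28 log units; within the scatter) and remains only an estimate. Compound 4 is expected at about 12 ug/mL within an estimated range of 3 ug/mL to 35 ug/mL and that range is deliberately wide.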

Compound 4, solubility: 7.6 ug/mL
For compound 4 the middle estimate is 1.6-fold (0.20 log units) above the measured one; the measured number falls inside the stated range.
By their numbers in this assay, from the lowest: compound 3; then compound 2; then compound 4; then compound 1.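

In this assay, the group on the carbonyl carbon now has a measured step of its own: furan-3-yl in place of oxolan-3-yl gives a 3.0-fold lower number from compound 1 to compound 4 (0.48 log units; beyond the scatter) and so moves the number by more than repeat measurements usually would. For the compounds shown here, until now, the only single-place step was the large one on an aromatic carbon, a 16-fold lower number from compound 1 to compound 2 (1.22 log units; beyond the scatter), whereas this new step is modest and shows that the other end of the molecule also matters. The exchange leaves the counts of heavy atoms, hydrogen-bond donors and hydrogen-bond acceptors unchanged, but it makes the ring aromatic and removes the defined stereocentre, and no measurement shown explains the step or separates these two differences.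

On these data alone, it remains open how the number would respond if this carbonyl carbon carried an amine, a carboxylic acid or a longer chain instead of either ring. It is also open whether furan-3-yl would give a step of similar size with trifluoromethyl on the aromatic ring, as in compound 2, because the compounds shown contain no such pair.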